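A few compounds are considered here, and "the series" means these few. Any claim that something is new, unique, unknown or untested is made for them only; others in the source may bear on it.

Working notes on the series, read in an ADME assay on Vero cells (Chlorocebus sabaeus) for cytotoxicity, read by MTT assay, with a stated time of 96 h; on this read-out lower numbers stand for higher toxicity in this test and higher numbers for lower toxicity in this test. Among the compounds with values here, compound 1 (`COc1ccc(-c2nc3cc(/C(C)=N/NC(N)=O)ccc3[nH]2)cc1`) gives "not determined" (no result reported), so compound 2 (`C/C(=N\NC(N)=S)c1ccc2[nH]c(-c3ccc(C(F)(F)F)cc3)nc2c1`), at 22000 nM, holds the only number available and has no measured neighbour for comparison. Compound 3 (`COc1ccc(-c2nc3cc(/C(C)=N/NC(N)=S)ccc3[nH]2)cc1`) differs from compound 2 by methoxy in place of trifluoromethyl on an aromatic carbon. Within the data shown here, no measured step covers this change, so the expected step of a 1.4-fold higher number from compound 2 to compound 3 (0.13 log units; within the scatter) stays within the scatter. For compound 3 the estimate is 30000 nM, with an expected range of 10000 nM to 90000 nM.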

Compound 3, half-maximal cytotoxic concentration: > 100000 nM
Compound 3 gave a limit, no number; the forecaster's own chance of this, stated with the estimate: 20%; middle value at least 3.3-fold (0.52 log units) away from the limit.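

In this assay, within the data shown here, methoxy in place of trifluoromethyl on an aromatic carbon, para to a large group, gives an at least 4.5-fold higher number from compound 2 to compound 3 (0.65 log units; beyond the scatter), the first measured step at this position. Compound 3 gives > 100000 nM, which is a limit of the assay and not a number. The full size of the step therefore stays unread: the limit of > 100000 nM in this assay, at which 1 of the 3 values shown sits.

Open, from the compounds shown here alone, is how an amine or a carboxylic acid at this position would read. With a carbonyl in place of the thiocarbonyl of compound 3, compound 1 gives "not determined" (no result reported), so that change cannot be read.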